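This account rests on a few compounds, and the source may have more. Where it says the series, first, only, none or still open, it means among the compounds named here.

Among the measured compounds shown here, in a functional assay on HeLa cells (Homo sapiens) for inhibition, read by MTT assay, with a stated time of 72 h (on this read-out higher numbers stand for weaker inhibition and lower numbers for stronger inhibition), compound 1 (`COc1ccc(-c2nnc(SCCCN3CCN(c4nc5ccccc5o4)CC3)o2)cc1`) gives 210000 nM and compound 2 (`Oc1ccc(-c2nnc(SCCCN3CCN(c4nc5ccccc5o4)CC3)o2)cc1`) gives 99500 nM as the lowest of the two numbers measured so far, which makes compound 2 the stronger inhibitor of this pair. Compound 3 (`O=C(NCc1nnc(SCCCN2CCN(c3nc4ccccc4o3)CC2)o1)c1ccccc1`) keeps the shared core, but the group on an aromatic carbon of the five-membered aromatic ring changes: benzamidomethyl in place of 4-hydroxyphenyl on an aromatic carbon is the full count, benzamidomethyl in place of 4-hydroxyphenyl. For the measured compounds named here, only one measured step bears on this, and only loosely. Replacing methyl with hydrogen on an oxygen on an aromatic ring gave a 2.1-fold lower number from compound 1 to compound 2 (0.32 log units; beyond the scatter) as a modest change. Going by the values given here, that step altered a small part of the group now leaving, whereas compound 3 replaces the whole group, and no measured pair tests such a swap. Among the compounds with values here, the direction therefore stays open, and the expectation rests on compound 2 at 99500 nM and compound 1 at 210000 nM as the only guides. The estimated change is a 1.3-fold higher number from compound 2 to compound 3 (0.12 log units; within the scatter) in this assay and is expected to be small. The expected value for compound 3 is 130000 nM with an estimated range from 40000 nM to 350000 nM around it.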

Compound 3, half-maximal inhibitory concentration: 63900 nM
Beside the measured number, compound 3's estimate is 2.0-fold (0.31 log units) above it, and the stated range covers the measured number.
By their numbers in this assay, from the lowest: compounds 3 and 2 (each within the scatter of the next); then compound 1.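

In this assay, a whole-group swap at this position gives a 1.6-fold lower number from compound 2 to compound 3 (0.19 log units; within the scatter), so benzamidomethyl, with 10 heavy atoms and a nitrogen, cannot be told apart from 4-hydroxyphenyl, with 7 heavy atoms. Set against 4-methoxyphenyl, the same group gives a 3.3-fold lower number from compound 1 to compound 3 (0.52 log units; beyond the scatter), a modest step that, unlike the earlier change on the oxygen, involves replacing the entire group on the aromatic carbon. The position therefore accepts a quite different group without losing inhibition in this set, although no measurement here offers an explanation for these numbers.

The compounds shown leave open which part of benzamidomethyl matters, the amide or its six-membered aromatic ring, since the two parts always occur together here. Going by these compounds, it also remains unknown how this position would respond to a simple amine, a carboxylic acid or a longer chain between the amide and the ring, so the three compounds give only a narrow view of what it can hold.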